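The source may report more compounds than this note shows. Statements on the series, on what has been measured and on what is new or still open speak of the compounds shown alone.

In an ADME assay on cells (Macrophage, Mus musculus) for cytotoxicity, read by resazurin assay, with a stated time of 3 days (on this read-out lower numbers stand for stronger inhibition and higher numbers for weaker inhibition), compound 1 `O=C(Nc1cc(C(F)(F)F)ccc1C(F)(F)F)c1cc(Cl)ccc1O` gives 6600 nM and compound 2 `O=C(Nc1cccc(F)c1)c1cc(Cl)ccc1O` gives 15000 nM, the higher of the two numbers, with a gap beyond the usual scatter. Compound 3 `N#Cc1cccc(NC(=O)c2cc(Cl)ccc2O)c1` has not yet been measured. It differs from compound 2 in one place, with cyano in place of fluoro on an aromatic carbon, meta to a large group: cyano in place of fluoro on an aromatic carbon. Within the data shown here, no pair of measured compounds isolates a single change, so no measured step speaks directly to this swap. Among the measured compounds shown here, the only guide is that compound 1 at 6600 nM and compound 2 at 15000 nM carry different substitution on the shared core. In this assay, no step beyond the scatter is expected, with a slight lean towards a lower number. The expected change is a 1.3-fold lower number from compound 2 to compound 3 (0.10 log units; within the scatter). Compound 3 is expected at 12000 nM, with an estimated range of 5000 nM to 28000 nM.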

Compound 3, half-maximal inhibitory concentration: 10000 nM
The estimate for compound 3 lay 1.2-fold (0.08 log units) above the measured number; the measured number falls inside the stated range.
By their numbers in this assay, from the lowest: compounds 1, 3 and 2 (each within the scatter of the next, the first and the last beyond it).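

In this assay, cyano in place of fluoro on an aromatic carbon, meta to a large group, gives a 1.5-fold lower number from compound 2 to compound 3 (0.18 log units; within the scatter), so at this position the exchange of these two groups produces no step beyond the scatter. Among these compounds, this is the first measured change confined to one place on the shared core, as compound 1 and compound 2 differ in more than one place and could not isolate any single group. No measured evidence is available to explain the size of this step.

Going by these compounds, whether this position stays as flat with an amine, a carboxylic acid or a longer chain remains open. Also open is what each trifluoromethyl group contributes in compound 1, at 6600 nM, as no single-place step links it to the other compounds shown.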